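A few compounds are considered here, and "the series" means these few. Any claim that something is new, unique, unknown or untested is made for them only; others in the source may bear on it.

In a functional assay on MDA-MB-231 cells (Homo sapiens) for antiproliferative activity, read by sulforhodamine B assay, with a stated time of 72 h (on this read-out lower numbers stand for stronger inhibition and higher numbers for weaker inhibition), two compounds have been measured. Compound 1 `Fc1ccc(/C=C\c2cc3ccccc3nc2Cl)cc1` gives 24000 nM, and compound 2 `FC(F)(F)c1ccc(/C=C\c2cc3ccc(Cl)cc3nc2Cl)cc1` gives 13600 nM. Compound 2 stands at the lower of the two numbers, but its gap to compound 1 lies within the usual scatter, so neither compound can be called the more active one on this evidence. The next compound, compound 3 `Fc1ccc(/C=C\c2cc3ccc(Cl)cc3nc2Cl)cc1`, keeps the core of compound 2 and differs from it in one place: fluoro in place of trifluoromethyl on an aromatic carbon. Among the measured compounds shown here, no measured pair in this set shows what this change does. Compound 3 carries the same fluoro as compound 1 while keeping the chloro on the core of compound 2. The expected step in this assay from compound 2 to compound 3 is a 1.5-fold higher number from compound 2 to compound 3 (0.17 log units; within the scatter), a modest rise in the number that stays within the scatter. Compound 3 is therefore expected to give about 20000 nM in this assay, within a range of 8000 nM to 50000 nM.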

Compound 3, half-maximal inhibitory concentration: 42600 nM
Compound 3: middle estimate off by 2.1-fold (0.33 log units), on the low side, within the range that was stated.
By their numbers in this assay, from the lowest: compounds 2, 1 and 3 (each within the scatter of the next, the first and the last beyond it).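

In this assay, among the compounds shown here, fluoro in place of trifluoromethyl on the aromatic carbon para to a large group gives a 3.1-fold higher number from compound 2 to compound 3 (0.50 log units; beyond the scatter) and this is the first step in the set that lies beyond the scatter, so on the chloro-bearing core this position does respond to the change of group. Chloro in place of hydrogen on an aromatic carbon, with the fluoro kept, gives a 1.8-fold higher number from compound 1 to compound 3 (0.25 log units; within the scatter) and so does not separate those two compounds. Nothing available bears on why the exchange of trifluoromethyl for fluoro moves the number.

The compounds shown leave open whether trifluoromethyl holds the same advantage over fluoro on the core without the chloro. They also leave open how other groups on this aromatic carbon, such as a methoxy, a nitrile or an amine, would compare with trifluoromethyl.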